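A few compounds are considered here, and "the series" means these few. Any claim that something is new, unique, unknown or untested is made for them only; others in the source may bear on it.

Compound 1 `COc1ccc(S(=O)(=O)N2CCc3cccc(NC(=O)c4ccc([N+](=O)[O-])cc4)c32)cc1`: 116 nM
Compound 2 `COc1ccc(S(=O)(=O)N2CCc3cccc(NC(=O)c4ccc(F)cc4)c32)cc1`: 100 nM

In a functional assay on TSGH 9201 cells (Homo sapiens) for cytotoxicity (a lower number here means a stronger inhibitor, a higher number a weaker inhibitor), compound 2 gives 100 nM, and it stands level with compound 1 at 116 nM. Among the compounds with values here, the only measured step, a 1.2-fold lower number from compound 1 to compound 2 (0.06 log units; within the scatter), lies within the scatter. Compound 3 `COc1ccc(S(=O)(=O)N2CCc3cccc(NC(=O)c4ccncc4)c32)cc1` has not yet been measured. It keeps the shared core and carries pyridin-4-yl in place of 4-fluorophenyl on a carbonyl carbon.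

The measured step bears on this change only loosely. Within the data shown here, it exchanges fluoro and nitro on an aromatic carbon, while here the aromatic ring itself is replaced, and no measured step covers that. The data therefore fix neither size nor direction, and a modest move towards a lower number is only a tentative expectation. The expected step is a 2.0-fold lower number from compound 2 to compound 3 (0.30 log units; within the scatter). For compound 3 the estimated value is 50 nM, with an expected range from 12 nM to 200 nM.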

Compound 3, half-maximal inhibitory concentration: 10.8 nM
Compound 3: the middle estimate sits 4.6-fold (0.67 log units) above what was measured; measured number below the stated range.
By their numbers in this assay, from the lowest: compound 3; then compounds 2 and 1 (each within the scatter of the next).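

In this assay pyridin-4-yl in place of 4-fluorophenyl on the carbonyl carbon gives a 9.3-fold lower number from compound 2 to compound 3 (0.97 log units; beyond the scatter) and pyridin-4-yl in place of 4-nitrophenyl gives an 11-fold lower number from compound 1 to compound 3 (1.03 log units; beyond the scatter) at the same place. The earlier exchange of nitro for fluoro, a 1.2-fold lower number from compound 1 to compound 2 (0.06 log units; within the scatter), had shown no measurable response at this position, whereas replacing the carbon-only aromatic ring with one holding a ring nitrogen moves the number well beyond the scatter. Nothing available accounts for the size of this gain.

The compounds shown leave open whether the gain belongs to the ring nitrogen itself or to the removal of the fluoro or nitro group, a question that an unsubstituted phenyl would separate. As far as these compounds go, whether the place of that nitrogen matters also remains open, and pyridin-3-yl or pyridin-2-yl would address it.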